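Replacing the large chain group of compound 2

The source may hold more compounds than are shown below. What is called first, only, known or untested is meant among the compounds shown, and "the series" means these compounds.

Compound 1 `N=c1sc2cc(OC(F)(F)F)ccc2n1CCS(=O)(=O)O` and compound 2 `N=c1sc2cc(OC(F)(F)F)ccc2n1CC[S+]([O-])c1ccccc1` share one core and differ in the group on their chain. In a functional assay on the whole organism with Rattus norvegicus as the target (on this read-out higher numbers stand for an effect only at larger amounts of compound and lower numbers for an effect already at smaller amounts), compound 1 gives > 10 mg/kg as its entry, which is a limit of the assay and not a number. In this assay, among the compounds with values here, compound 2 gives 4.2 mg/kg as the only true number available, so no other number stands beside it for comparison.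

Compound 3 `CSCCCn1c(=N)sc2cc(OC(F)(F)F)ccc21` is altered at the same place, and a group of 3 heavy atoms (2 carbon, 1 sulfur; no ring) in place of a group of 8 heavy atoms (6 carbon, 1 oxygen, 1 sulfur; one six-membered aromatic ring of carbon only), on a saturated chain carbon, two bonds along the chain from an aromatic nitrogen sets it apart from compound 2. Within the data shown here, the only measured step at this place is an at least 2.3-fold lower number from compound 1 to compound 2 (0.37 log units; beyond the scatter) and it concerns a different exchange. For compound 1 that step starts from the limit of > 10 mg/kg in this assay, at which 1 of the 2 values shown sits, and no exact size can be read from it. It therefore gives no size for the new exchange, and no step beyond the scatter is expected in this assay here. The estimate is anchored on compound 2 at 4.2 mg/kg as the nearest number. The expected step is a 1.2-fold lower number from compound 2 to compound 3 (0.08 log units; within the scatter) in this estimate. For compound 3 the expected value is 3.5 mg/kg with an estimated range from 1.2 mg/kg to 10 mg/kg on this read-out.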

Compound 3, dose for half-maximal effect: 4.2 mg/kg
Beside the measured number, compound 3's estimate is 1.2-fold (0.08 log units) below it, within the range that was stated.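

In this assay there is no change at the digits printed from compound 2 to compound 3 (within the scatter), so at this place, on a saturated chain carbon, two bonds along the chain from an aromatic nitrogen, the six-membered aromatic ring of compound 2 can give way to the much smaller (methylsulfanyl)methyl group with no difference beyond the scatter. The exchange of sulfo for (methylsulfanyl)methyl gives an at least 2.3-fold lower number from compound 1 to compound 3 (0.37 log units; beyond the scatter), which shows that a second, ring-free group also reaches a true number where the sulfo group does not. The size of that step has only a lower bound, since compound 1 stands at a limit of the assay and not at a number: the limit of > 10 mg/kg in this assay, at which 1 of the 3 values shown sits.

The compounds shown do not tell whether an amine or a carboxylic acid at this place would behave like the sulfo group of compound 1 or like the groups of compound 2 and compound 3. They also leave open what a simple methyl group, with no sulfur at all, or a longer chain would do on this read-out.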